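The source may hold more compounds than are shown below. What is called first, only, known or untested is meant among the compounds shown, and "the series" means these compounds.

For the measured compounds named here, in a functional assay on A549 cells (Homo sapiens) for cytotoxicity, read by MTT assay (a higher number here means a weaker inhibitor, a lower number a stronger inhibitor), three compounds have numbers so far: compound 1 `O=c1oc2ccccc2c(O)c1-c1cc(-c2c(F)cccc2Cl)nc(O)n1` gives 5100 nM, compound 2 `COc1cccc(-c2cc(-c3c(O)c4ccccc4oc3=O)nc(S)n2)c1` gives 10200 nM and compound 3 `O=c1oc2ccccc2c(O)c1-c1cc(-c2ccc(F)cc2)nc(S)n1` gives 21100 nM. Compound 3 therefore stands highest of the three, with compound 2 nearest to it and compound 1 furthest away. Compound 4 `O=c1oc2ccccc2c(O)c1-c1cc(-c2c(F)cccc2Cl)nc(S)n1` has not yet been measured. It differs from compound 3 in one place, with 2-chloro-6-fluorophenyl in place of 4-fluorophenyl on an aromatic carbon. Going by the values given here, only one measured step changes this same place, a 2.1-fold higher number from compound 2 to compound 3 (0.32 log units; beyond the scatter), and it is modest. Among the compounds with values here, no measured step makes the exact exchange in question. The nearest guide is compound 1, which at 5100 nM already carries the 2-chloro-6-fluorophenyl group but differs from compound 4 elsewhere. A modest move toward a lower number therefore seems likely, and the expected step is a 2.2-fold lower number from compound 3 to compound 4 (0.35 log units; beyond the scatter). For compound 4 the estimated value in this assay is 9500 nM, with an expected range of 3500 nM to 24000 nM.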

Compound 4, half-maximal inhibitory concentration: 3980 nM
Estimate against measurement, compound 4: 2.4-fold (0.38 log units) above; measured number inside the range.
By their numbers in this assay, from the lowest: compounds 4, 1 and 2 (each within the scatter of the next, the first and the last beyond it); then compound 3.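

In this assay, for the compounds shown here, the aromatic carbon of the ring with two nitrogens proves more responsive than the one earlier step suggested: 2-chloro-6-fluorophenyl in place of 4-fluorophenyl gives (a 5.3-fold lower number from compound 3 to compound 4 (0.72 log units; beyond the scatter)), and in place of 3-methoxyphenyl it gives (a 2.6-fold lower number from compound 2 to compound 4 (0.41 log units; beyond the scatter)). Going by these compounds alone, with 2-chloro-6-fluorophenyl held constant, the other position can now be read for the first time, and sulfanyl in place of hydroxy gives (a 1.3-fold lower number from compound 1 to compound 4 (0.11 log units; within the scatter)). Nothing available here explains why the aryl exchange shifts the number.

The compounds shown do not separate the chlorine from the fluorine, so it stays open whether the step needs both or only one of them. They also leave open how an aryl ring bearing an amine or a carboxylic acid would read at this carbon.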